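The compounds below may be only part of what the source reports. "The series", "measured", "known", "first", "only" and "open" are said of these compounds alone.

Values measured in a functional assay (Homo sapiens) (on this read-out lower numbers stand for stronger inhibition and higher numbers for weaker inhibition), follow
compound 1 `Nc1nc2ccnc(-c3cccc(C(F)(F)F)c3)n2n1` gives 2200 nM; 2200 nM (2 entries)
compound 2 `Nc1nc2ccnc(-c3cccnc3)n2n1` gives 14000 nM
compound 3 `Cc1cnc(-c2cccc(C(F)(F)F)c2)n2nc(N)nc12` gives 5600 nM

Compound 2 stands at 14000 nM and compound 3 stands at 5600 nM, and compound 3 is the lower of the two by a gap beyond the scatter. Compound 1 stands at 2200 nM; 2200 nM (2 entries), and compound 3 lies higher on the same scale. Compound 4 `Cc1cnc(-c2cccc([N+](=O)[O-])c2)n2nc(N)nc12` is still to be measured. It differs from compound 3 by nitro in place of trifluoromethyl on an aromatic carbon meta to a large group (nitro in place of trifluoromethyl on an aromatic carbon). For the measured compounds named here, no measured pair isolates this change. In this assay no step beyond the scatter is expected, and neither direction is favoured. The expected step is small (a 1.2-fold higher number from compound 3 to compound 4 (0.06 log units; within the scatter)). For compound 4 the estimated value is 6500 nM with an expected range from 2200 nM to 19000 nM on this read-out.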

Compound 4, half-maximal inhibitory concentration: 8700 nM
Estimate against measurement, compound 4: 1.3-fold (0.13 log units) below; low and high end bracket the measured number.
By their numbers in this assay, from the lowest: compounds 3, 4 and 2 (each within the scatter of the next, the first and the last beyond it).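

In this assay, for the compounds shown here, nitro in place of trifluoromethyl on an aromatic carbon gives a 1.6-fold higher number from compound 3 to compound 4 (0.19 log units; within the scatter) and is the first step that isolates a change at this place. On this single pair the read-out does not separate the two groups, so trifluoromethyl is not singled out here over nitro. Open, as far as these compounds go, is whether the same holds on the core of compound 1, and how a nitrile, an amine or a carboxylic acid would read at this place. Nothing at hand explains the result.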